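Adding methoxy to compound 3

A few compounds are considered here, and "the series" means these few. Any claim that something is new, unique, unknown or untested is made for them only; others in the source may bear on it.

In a functional assay on A549 cells (Homo sapiens) for antiproliferative activity, read by CCK-8 assay, with a stated time of 72 h (a higher number here means a weaker inhibitor, a lower number a stronger inhibitor), compound 3 (`Nc1ccccc1NC(=O)c1ccc(COc2ccccc2)cc1`) gives 6760 nM, the lower of the two numbers available. Compound 1 (`O=C(NO)c1ccc(COc2ccccc2)cc1`) gives 28000 nM, and for compound 2 (`Nc1ccccc1NC(=O)c1ccc(CN2CCc3cc(Br)ccc32)cc1`) the entry reads "not determined" (no result reported). Compound 4 (`COc1ccc(OCc2ccc(C(=O)Nc3ccccc3N)cc2)cc1`) carries methoxy in place of hydrogen on an aromatic carbon of compound 3, para to a large group: methoxy in place of hydrogen on an aromatic carbon. Going by the values given here, the only measured step, a 4.1-fold lower number from compound 1 to compound 3 (0.62 log units; beyond the scatter), puts 2-aminophenyl in place of hydroxy on an amide-type nitrogen, so it does not bear directly on this change. Among the compounds with values here, no measured step involves methoxy, so a step beyond the scatter is not expected in this assay, and the expectation stays near compound 3 at 6760 nM. The estimated step is a 1.1-fold lower number from compound 3 to compound 4 (0.05 log units; within the scatter). For compound 4 the expected value is 6000 nM, within an estimated range of 2000 nM to 18000 nM.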

Compound 4, half-maximal inhibitory concentration: 5530 nM
Estimate against measurement, compound 4: 1.1-fold (0.04 log units) above, and the stated range covers the measured number.
By their numbers in this assay, from the lowest: compounds 4 and 3 (each within the scatter of the next); then compound 1.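

In this assay, going by these compounds alone, the change from phenyl to 4-methoxyphenyl, with methoxy on the aromatic carbon para to a large group, gives a 1.2-fold lower number from compound 3 to compound 4 (0.09 log units; within the scatter) as the first measured step at this position. The position therefore takes methoxy without a step beyond the scatter, whereas the earlier step concerned only the group on the amide-type nitrogen. No evidence on the reason for this result is available. On these data alone, whether an amine, a carboxylic acid or a longer chain at this position would also stay within the scatter remains open. So does whether methoxy would give a similar step on compound 1, which carries hydroxy on that nitrogen.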